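Moving the Fluorine in Two Related Pairs

This account rests on a few compounds, and the source may have more. Where it says the series, first, only, none or still open, it means among the compounds named here.

Compound 1 `O=C(C1COc2ccccc2O1)N1N=C(c2ccc(Br)cc2)CC1c1ccccc1F` gives 8030 nM in a functional assay on WM 266-4 cells (Homo sapiens) for inhibition, read by MTT assay, with a stated time of 24 h; a lower number here means a stronger inhibitor of growth, a higher number a weaker inhibitor of growth. Compound 2 `O=C(C1COc2ccccc2O1)N1N=C(c2ccc(Br)cc2)CC1c1cccc(F)c1` gives 7810 nM in this assay. The change 3-fluorophenyl in place of 2-fluorophenyl on a saturated ring carbon made a step of a 1.0-fold lower number from compound 1 to compound 2 (0.01 log units; within the scatter). Compound 3 `COc1ccc(C2=NN(C(=O)c3ccc4c(c3)OCCO4)C(c3ccccc3F)C2)cc1` gives 3470 nM in this assay; its number is lower than those of compound 1 and of compound 2, and both gaps lie beyond the scatter. The difference between the core of compound 1 and the core of compound 3 is not broken down here. Compound 4 `COc1ccc(C2=NN(C(=O)c3ccc4c(c3)OCCO4)C(c3cccc(F)c3)C2)cc1` differs from compound 3 by 3-fluorophenyl in place of 2-fluorophenyl on a saturated ring carbon; here the ring atom two ring bonds away bears a 4-methoxyphenyl group rather than a 4-bromophenyl group, so this is the same kind of change, not the same one. Because the earlier step was a 1.0-fold lower number from compound 1 to compound 2 (0.01 log units; within the scatter), compound 4 is expected to show a step of a 1.0-fold lower number from compound 3 to compound 4 (0.01 log units; within the scatter) in this assay. The estimate for compound 4 is 3400 nM, between 1500 nM and 7500 nM.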

Compound 4, concentration for 50% growth inhibition: 930 nM
For compound 4 the middle estimate is 3.7-fold (0.56 log units) above the measured one; measured number outside the range, below it.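

With the core of compound 3, 3-fluorophenyl in place of 2-fluorophenyl gave a 3.7-fold lower number from compound 3 to compound 4 (0.57 log units; beyond the scatter) in this assay. Among these compounds, the same change therefore did not carry over from one core to the other with the same size, and the near-absent step on the first core gave no guide to the step on the second: the same change on two cores in this assay, a 1.0-fold lower number (0.01 log units; within the scatter) from compound 1 to compound 2 and a 3.7-fold lower number (0.57 log units; beyond the scatter) from compound 3 to compound 4, 3.6-fold (0.56 log units) apart, beyond the scatter of two such steps. Among the compounds shown here, with only two pairs, this does not show which difference between the cores goes with the larger step, or how the change would behave on any further core.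

The compounds shown leave open how a phenyl group without fluorine, or a 3-chlorophenyl group, would compare on these two cores. They also leave open whether a 4-chlorophenyl group in place of the 4-methoxyphenyl group would give the larger step or the near-absent one.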